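The compounds below may be only part of what the source reports. "The series", "measured", "known", "first", "only" and "open" are said of these compounds alone.

Measured so far, in an assay with Norepinephrine transporter (Rattus norvegicus) as the target; a higher number here means a weaker inhibitor, a lower number a stronger inhibitor:

compound 1 `COC(=O)C1C2CCC3CCC1N(C/C2=C\c1ccc(-c2ccc(C)cc2)cc1)C3` gives 22.7 nM
compound 2 `COC(=O)C1C2CCC3CCC1N(C/C2=C\c1ccc(-c2ccc(C#N)cc2)cc1)C3` gives 32.4 nM
compound 3 `COC(=O)C1C2CCC3CCC1N(C/C2=C\c1ccc(-c2cccs2)cc1)C3` gives 19.8 nM

Compound 3 has the smallest number of the three, yet neither compound 1 nor compound 2 differs from it beyond the scatter. Compound 4 `COC(=O)C1C2CCC3CCC1N(C/C2=C\c1ccc(-c2ccsc2)cc1)C3` differs from compound 3 by thiophen-3-yl in place of thiophen-2-yl on an aromatic carbon. Going by the values given here, the steps that bear on this place are a 1.1-fold lower number from compound 1 to compound 3 (0.06 log units; within the scatter) and a 1.6-fold lower number from compound 2 to compound 3 (0.21 log units; within the scatter), both within the scatter, and the step of a 1.4-fold higher number from compound 1 to compound 2 (0.15 log units; within the scatter) is also within it: every change made at this position so far has left this assay essentially unchanged. The step of a 1.1-fold higher number from compound 3 to compound 4 (0.05 log units; within the scatter) is therefore expected to be none beyond the scatter. Compound 4 is estimated at 22 nM, with a range from 10 nM to 48 nM.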

Compound 4, inhibition constant: 20.5 nM
For compound 4 the middle estimate is 1.1-fold (0.03 log units) above the measured one, within the range that was stated.
By their numbers in this assay, from the lowest: compounds 3, 4, 1 and 2 (each within the scatter of the next).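

Swapping thiophen-2-yl for thiophen-3-yl joins the same atoms differently, and in this assay this rearrangement changes nothing measurable (a 1.0-fold higher number from compound 3 to compound 4 (0.02 log units; within the scatter)). Compound 4 also stays within the scatter of the compounds with six-membered aromatic rings at this place (a 1.6-fold lower number from compound 2 to compound 4 (0.20 log units; within the scatter); a 1.1-fold lower number from compound 1 to compound 4 (0.04 log units; within the scatter)), so the way the thiophene is attached matters no more here than the choice of ring. No measurement shown accounts for this flatness. Every group shown here is an aromatic ring, so what an amine, a carboxylic acid or a longer chain would do at this place remains open.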